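This account rests on a few compounds, and the source may have more. Where it says the series, first, only, none or still open, it means among the compounds named here.

Measured in a functional assay on MDA-MB-231 cells (Homo sapiens) for cytotoxicity, read by MTT assay, with a stated time of 48 h; on this read-out higher numbers stand for weaker inhibition and lower numbers for stronger inhibition:
- compound 1 `O=C(N/N=C/c1c[nH]c2ccc(Br)cc12)C(=O)c1c[nH]c2ccccc12`: 5600 nM
- compound 2 `O=C(N/N=C/c1c[nH]c2ccccc12)C(=O)c1cn(Cc2ccc(Cl)cc2)c2ccccc12`: 500 nM

Of these two numbers, compound 2 holds the lower at 500 nM, and the gap to compound 1 lies beyond the scatter of repeated measurements. The next compound, compound 3 `COc1ccc2[nH]cc(/C=N/NC(=O)C(=O)c3cn(Cc4ccc(Cl)cc4)c4ccccc34)c2c1`, departs from compound 2 by a single change, methoxy in place of hydrogen on an aromatic carbon. Going by the values given here, no measured pair shows this change on its own, so the data offer no direct guide to its effect. In this assay, a step beyond the scatter is therefore not expected, and any movement is expected to be slightly downward. The expected change is a 1.3-fold lower number from compound 2 to compound 3 (0.10 log units; within the scatter). For compound 3 the estimated value is 400 nM, with an expected range from 120 nM to 1300 nM.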

Compound 3, half-maximal inhibitory concentration: 2900 nM
Compound 3: the middle estimate sits 7.3-fold (0.86 log units) below what was measured, outside the stated range (above it).
By their numbers in this assay, from the lowest: compound 2; then compounds 3 and 1 (each within the scatter of the next).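

In this assay, going by these compounds alone, methoxy in place of hydrogen on this aromatic carbon, meta to a fused ring and para to a fused ring, brings a 5.8-fold higher number from compound 2 to compound 3 (0.76 log units; beyond the scatter) and gives the first direct reading of a change at this position. With the rest of compound 2 unchanged, the step from 1H-indol-3-yl to 5-methoxy-1H-indol-3-yl weakens inhibition, so this carbon does not tolerate every replacement of its hydrogen. Nothing available explains the loss.

Going by these compounds, it remains open whether this weakening is particular to methoxy or extends to other groups on the same carbon, such as hydroxy, fluorine or an amine. A single step also cannot show whether methoxy on another carbon of this ring would read the same way.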